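The source may report more compounds than this note shows. Statements on the series, on what has been measured and on what is new or still open speak of the compounds shown alone.

In a functional assay on HepG2 cells (Homo sapiens) for cytotoxicity, read by MTT assay (on this read-out higher numbers stand for weaker inhibition and lower numbers for stronger inhibition), compound 1 `CC1(C)C=Cc2c([C@H]3CCc4ccc(O)cc4O3)ccc(O)c2O1` reads > 100000 nM, which is a limit of the assay and not a number. Among the compounds with values here, compound 2 `CC1(C)C=Cc2c(C3CCc4ccc(O)cc4O3)ccc(O)c2O1` gives 92800 nM, the only true number so far. Compound 3 `CC1(C)C=Cc2c([C@@H]3CCc4ccc(O)cc4O3)ccc(O)c2O1` changes only the drawn stereochemistry: the two compounds have the same atoms and bonds; at least one stereo element is drawn with a configuration in one of them and without one in the other: 1 of 1 stereo elements differ; a stereocentre at a saturated ring carbon is drawn without a configuration in compound 2 and S in compound 3. Within the data shown here, the one measured step at this stereocentre, an at least 1.0-fold lower number from compound 1 to compound 2 (0.03 log units; that floor lies within the scatter), is small, though it rests on a limit, and it separates compound 1, drawn R, from compound 2. No step beyond the scatter is therefore expected, and the estimate is a 1.0-fold lower number from compound 2 to compound 3 (0.01 log units; within the scatter). For compound 3, the expected value is 90000 nM, within an estimated range of 50000 nM to 140000 nM.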

Compound 3, half-maximal inhibitory concentration: > 100000 nM
Compound 3: only a limit was reported (the forecaster's own chance of this, stated with the estimate: 45%); middle value at least 1.1-fold (0.04 log units) from the limit.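

Compound 3, drawn S, joins compound 1, drawn R, so in this assay both drawn forms of this stereocentre now rest on a limit rather than a number. Setting the configuration to S gives an at least 1.0-fold higher number from compound 2 to compound 3 (0.03 log units; that floor lies within the scatter), a floor that shows no step beyond the scatter. The step between compound 1 and compound 3 cannot be read because both values are limits: the limit of > 100000 nM in this assay, at which 2 of the 3 values shown sit.

As far as these compounds go, whether either drawn form truly differs from the other stays open. So does whether an amine or a carboxylic acid on the shared core would give a true number under this limit.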